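This account rests on a few compounds, and the source may have more. Where it says the series, first, only, none or still open, it means among the compounds named here.

Measured so far:
Compound 1 `Cc1cc2nc(-c3cc4ccccc4[nH]c3=O)[nH]c2cc1C` gives > 100000 nM in a functional assay on SK-OV-3 cells (Homo sapiens) for cytotoxicity, read by MTT assay, with a stated time of 48 h; a lower number here means a stronger inhibitor, a higher number a weaker inhibitor; this is a limit of the assay, not a number.
Compound 2 `O=c1[nH]c2ccccc2cc1-c1nc2cc([N+](=O)[O-])ccc2[nH]1` gives > 100000 nM in this assay, again a limit of the assay.
Compound 3 `O=c1[nH]c2ccccc2cc1-c1nc2cc(Br)ccc2[nH]1` gives 11400 nM in this assay.

Compound 1 therefore stands at the limit of > 100000 nM in this assay, at which 2 of the 3 values shown sit; compound 3 is the only one of the three with a measured number. Compound 4 `COc1ccc2[nH]c(=O)c(-c3nc4cc(C)c(C)cc4[nH]3)cc2c1` differs from compound 1 by methoxy in place of hydrogen on an aromatic carbon. Going by the values given here, the one measured step, an at least 8.7-fold lower number from compound 2 to compound 3 (0.94 log units; beyond the scatter), concerns the other ring system of the shared core and a different pair of groups, so it does not bear on methoxy in place of hydrogen on the carbon-only ring. Among the compounds with values here, no measured step speaks to the change from compound 1 to compound 4, and since compound 1 sits at the limit, only a move toward stronger inhibition could show at all. Compound 4 is expected to stay weak, and an at least 1.6-fold lower number from compound 1 to compound 4 (0.22 log units; that floor lies within the scatter) is the expected step. The estimate for compound 4 in this assay is 60000 nM, with a range from 15000 nM to 300000 nM, and a real chance that only a limit is reported again.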

Compound 4, half-maximal inhibitory concentration: > 100000 nM
Compound 4: a limit, no number; the forecaster's own chance of this, stated with the estimate: 60%; at least 1.6-fold (0.22 log units) between middle value and limit.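

Compound 4 gives a limit of the assay, not a number: the limit of > 100000 nM in this assay, at which 3 of the 4 values shown sit. Compound 1 gives a limit too, so no step can be read between compound 1 and compound 4. The compounds shown leave open whether methoxy in place of hydrogen on an aromatic carbon changes this cytotoxicity at all.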